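Methyl to Isopropyl Amide Swap on a Second Core

A few compounds are considered here, and "the series" means these few. Any claim that something is new, unique, unknown or untested is made for them only; others in the source may bear on it.

Measured in a functional assay on Huh-7 cells (Homo sapiens) for antiproliferative activity, read by CCK-8 assay, with a stated time of 72 h; a higher number here means a weaker inhibitor of growth, a lower number a stronger inhibitor of growth:
compound 1, `CCC1C(=O)N(C)c2cnc(-n3ccc4cc(C(=O)NC(C)C)ccc43)nc2N1c1ccn(C)n1`: 6740 nM
compound 2, `CCC1C(=O)N(C)c2cnc(-n3ccc4cc(C(=O)NC)ccc43)nc2N1c1ccn(C)n1`: 13200 nM
compound 3, `CC[C@@H]1C(=O)N(C)c2cnc(-n3ccc4cc(C(=O)NC)ccc43)nc2N1C1CCCC1`: 842 nM

Compounds 1 and 2 share one core and differ only by isopropyl in place of methyl on an amide-type nitrogen. That change gave a 2.0-fold lower number from compound 2 to compound 1 (0.29 log units; within the scatter), a step that stays within the scatter of this assay. Compound 3 carries a different core; how its core differs from that of compound 2 is not broken down here. In this assay compound 3 gives the lowest of the three numbers, and its gap to compound 1 and to compound 2 lies beyond the scatter in each case.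

Compound 4, `CC[C@@H]1C(=O)N(C)c2cnc(-n3ccc4cc(C(=O)NC(C)C)ccc43)nc2N1C1CCCC1`, has not been measured. It differs from compound 3 by isopropyl in place of methyl on an amide-type nitrogen, the same change, at the same place, that separates compound 2 from compound 1. On the strength of the earlier step of a 2.0-fold lower number from compound 2 to compound 1 (0.29 log units; within the scatter), the step from compound 3 to compound 4 is expected to be a 1.7-fold lower number from compound 3 to compound 4 (0.23 log units; within the scatter), small and likely within the scatter. Compound 4 is therefore estimated at 500 nM, between 200 nM and 1200 nM.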

Compound 4, concentration for 50% growth inhibition: 1660 nM
For compound 4 the middle estimate is 3.3-fold (0.52 log units) below the measured one; measured number outside the range, above it.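

In this assay, isopropyl in place of methyl on the amide-type nitrogen gave a 2.0-fold higher number from compound 3 to compound 4 (0.29 log units; within the scatter), so on the core of compound 3 this change again stays within the scatter. Set beside the earlier step, it points the other way, and the two steps are further apart than the scatter of two such steps allows: the same change on two cores in this assay, a 2.0-fold lower number (0.29 log units; within the scatter) from compound 2 to compound 1 and a 2.0-fold higher number (0.29 log units; within the scatter) from compound 3 to compound 4, 3.9-fold (0.59 log units) apart, beyond the scatter of two such steps. This shows that the direction of the step on one core did not carry over to the other, but with a single pair on each core it does not show how the core shapes the step, and neither pair taken alone separates methyl from isopropyl.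

The compounds shown leave open how an ethyl group, a longer chain or a cyclopropyl group on the same amide nitrogen would behave on these two cores. They also leave open whether the same change on a third core would follow either pair.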